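This account rests on a few compounds, and the source may have more. Where it says the series, first, only, none or still open, it means among the compounds named here.

Measured so far in a functional assay on HeLa cells (Homo sapiens) for cytotoxicity, read by MTT assay, with a stated time of 72 h; a higher number here means a weaker inhibitor, a lower number a stronger inhibitor:
compound 1 `COc1ccc(C(=O)c2cc(OC)c(OC)c(OC)c2)cc1N` – 60 nM
compound 2 `COc1ccc(C(=O)c2cc(OC)c(OC)c(OC)c2)cc1NC(=O)/C=C/c1ccc(F)cc1` – 60 nM
compound 3 `COc1cc(C(=O)c2cc(OC)c(OC)c(OC)c2)cc(NC(=O)/C=C/c2ccc(F)cc2)c1OC` – 900 nM

Compound 2 and compound 1 differ by hydrogen in place of (2-(4-fluorophenyl)ethenyl)carbonyl on a nitrogen on an aromatic ring. The corresponding step is no change at the digits printed from compound 2 to compound 1 (within the scatter); on this core the amide and the free amine give numbers that cannot be told apart.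

Compound 3 carries the same amide as compound 2 on a different core. The difference between the two cores is methoxy in place of hydrogen on an aromatic carbon, and it carries the step of a 15-fold higher number from compound 2 to compound 3 (1.18 log units; beyond the scatter). Compound 3 therefore stands at the high end of the three numbers, with both other compounds beyond the scatter from it.

Compound 4 `COc1cc(C(=O)c2cc(OC)c(OC)c(OC)c2)cc(N)c1OC` has not yet been measured in this assay. It differs from compound 3 by hydrogen in place of (2-(4-fluorophenyl)ethenyl)carbonyl on a nitrogen on an aromatic ring. The place of the change is worded identically to that of the change from compound 2 to compound 1, so it is the same change, now made on the core of compound 3. Among the compounds here this change occurs twice, and its one measured instance is the step from compound 2 to compound 1, which stayed within the scatter.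

The expectation for compound 4 rests on that single instance. The step of no change at the digits printed from compound 3 to compound 4 (within the scatter) is expected to be small, since the same change gave no change at the digits printed from compound 2 to compound 1 (within the scatter). One prior instance on a different core is thin support, so the range is kept wide. Compound 4 is expected to give 900 nM in this assay, with the estimate spanning 350 nM to 2500 nM.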

Compound 4, half-maximal inhibitory concentration: 13500 nM
Compound 4: middle estimate off by 15-fold (1.18 log units), on the low side, outside the stated range (above it).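

In this assay, taking (2-(4-fluorophenyl)ethenyl)carbonyl off the nitrogen gives a 15-fold higher number from compound 3 to compound 4 (1.18 log units; beyond the scatter), so a step that stayed within the scatter on the core of compound 2 does not carry over to the core of compound 3: the same change on two cores in this assay, no change at the digits printed (within the scatter) from compound 2 to compound 1 and a 15-fold higher number (1.18 log units; beyond the scatter) from compound 3 to compound 4, 15-fold (1.18 log units) apart, beyond the scatter of two such steps

Read the other way, methoxy in place of hydrogen on an aromatic carbon gives a larger step on the free amino series, a 230-fold higher number from compound 1 to compound 4 (2.35 log units; beyond the scatter), than on the amide series, so that change does not carry over unchanged either: the same change on two cores in this assay, a 15-fold higher number (1.18 log units; beyond the scatter) from compound 2 to compound 3 and a 230-fold higher number (2.35 log units; beyond the scatter) from compound 1 to compound 4, 15-fold (1.18 log units) apart, beyond the scatter of two such steps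

These four compounds form a single square, so the two comparisons are one departure from additivity seen from two sides, not independent findings; they show that the two changes cannot be treated as separate increments here, but not why, nor whether the same holds on any other core.

As far as these compounds go, it remains open whether the amide's hold on activity on the core of compound 3 belongs to the (2-(4-fluorophenyl)ethenyl)carbonyl group in particular or to any acyl group on that nitrogen. An acetyl group on the same nitrogen of both cores would separate these two readings.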